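Chain homologation in a shared-core series: cytotoxicity notes

The source may hold more compounds than are shown below. What is called first, only, known or untested is meant among the compounds shown, and "the series" means these compounds.

Values in an ADME assay on Vero cells (Chlorocebus sabaeus) for cytotoxicity, read by reporter gene assay, with a stated time of 4 days (a lower number here means a stronger inhibitor, a higher number a weaker inhibitor), so far:
- compound 1, `CCCCCCCC(=O)NCC(C)(C)CC1=C(O)C(=O)c2ccccc2C1=O`, gives 18400 nM
- compound 2, `CCCCCCCCC(=O)NCC(C)(C)CC1=C(O)C(=O)c2ccccc2C1=O`, gives 16700 nM
- compound 3, `CCCCCCCCCC(=O)OCC(C)(C)CC1=C(O)C(=O)c2ccccc2C1=O`, gives 203000 nM

Compound 2 differs from compound 1 by methyl in place of hydrogen on a saturated chain carbon, seven bonds along the chain from a carbonyl carbon. The step is a 1.1-fold lower number from compound 1 to compound 2 (0.04 log units; within the scatter), so the two values cannot be ordered. Compound 3 gives the highest number of the three; the difference between its core and the core of compound 1 is not broken down here, and its distance from compound 1 and compound 2 lies beyond the scatter in both cases.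

Compound 4, `CCCCCCCCCCC(=O)OCC(C)(C)CC1=C(O)C(=O)c2ccccc2C1=O`, is not yet measured in this assay. It differs from compound 3 by methyl in place of hydrogen on a saturated chain carbon, nine bonds along the chain from a carbonyl carbon. This is the same kind of change as that from compound 1 to compound 2, but the place is not identical: there the added methyl sits seven bonds along the chain from a carbonyl carbon, here nine bonds along the chain from a carbonyl carbon.

Because a 1.1-fold lower number from compound 1 to compound 2 (0.04 log units; within the scatter), a step of about the same size is expected, namely a 1.1-fold lower number from compound 3 to compound 4 (0.03 log units; within the scatter). Compound 4 is therefore expected to give about 190000 nM in this assay, estimated between 95000 nM and 400000 nM.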

Compound 4, half-maximal inhibitory concentration: > 233000 nM
Compound 4 gave a limit, no number; the forecaster's own chance of this, stated with the estimate: 20%; at least 1.2-fold (0.08 log units) between middle value and limit.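

In this assay compound 4 gives > 233000 nM, which is a limit of the assay and not a number. Methyl in place of hydrogen, nine bonds along the chain from a carbonyl carbon, therefore reads only as a floor, an at least 1.1-fold higher number from compound 3 to compound 4 (0.05 log units; that floor lies within the scatter), and it sits beside the earlier step on the other core: the same change on two cores in this assay, a 1.1-fold lower number (0.04 log units; within the scatter) from compound 1 to compound 2 and an at least 1.1-fold higher number (0.05 log units; that floor lies within the scatter) from compound 3 to compound 4; the limit leaves it open whether they differ Nothing here sets the two cores apart for this change, yet carrying it from one core to the other with the same size is not established, as compound 4 stands at the edge of what the assay reports: the limit of > 233000 nM in this assay, at which 1 of the 4 values shown sits.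

The compounds shown leave open whether a longer chain on the core of compound 3 would give a number rather than a limit, and whether a longer chain on the core of compound 1 would keep its value in the same range. They also leave open what an amine or a carboxylic acid in place of the added methyl would do on either core.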